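The source may report more compounds than this note shows. Statements on the series, on what has been measured and on what is new or still open speak of the compounds shown alone.

Among the compounds with values here, in a functional assay on the whole organism (stomach) with Rattus norvegicus as the target (on this read-out lower numbers stand for an effect already at smaller amounts and higher numbers for an effect only at larger amounts of compound), compound 2 `N=C(S)CCCCN1N=C(c2ccccc2)CCC1=O` gives 100 mg/kg, the only number so far. Compound 1 `O=c1cccnn1CCC(=S)N1CCCC1` sits at the limit of > 100 mg/kg in this assay, at which 1 of the 2 values shown sits, so its value > 100 mg/kg is a limit of the assay and not a number. Compound 3 `N=C(S)CCCCCN1N=C(c2ccccc2)CCC1=O` differs from compound 2 by a group of 4 heavy atoms (2 carbon, 1 nitrogen, 1 sulfur; no ring) in place of a group of 3 heavy atoms (1 carbon, 1 nitrogen, 1 sulfur; no ring), on a saturated chain carbon, four bonds along the chain from an amide-type nitrogen in a ring. Within the data shown here, no measured step of this kind exists, so the step expected from compound 2 to compound 3 is no change at the digits printed from compound 2 to compound 3 (within the scatter), within the usual scatter and in no firm direction. Compound 3 is accordingly estimated near 100 mg/kg, between 50 mg/kg and 200 mg/kg.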

Compound 3, dose for half-maximal effect: 100 mg/kg
Compound 3: middle estimate and measured number agree at the digits printed; the range from low to high includes it.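

In this assay, within the data shown here, the group of 4 heavy atoms in place of the group of 3 heavy atoms gives no change at the digits printed from compound 2 to compound 3 (within the scatter), the first readable step. This place, on a saturated chain carbon, four bonds along the chain from an amide-type nitrogen in a ring, therefore tolerates this one change without a shift beyond the scatter. Compound 1 offers no number for comparison, only a limit: the limit of > 100 mg/kg in this assay, at which 1 of the 3 values shown sits.

A single step sets no trend. Still open, going by these compounds, is whether a longer chain, an amine or a carboxylic acid at this place would move the read-out in this assay beyond the scatter.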